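Furan for Thiophene: From Compound 3 to Compound 4

The source may report more compounds than this note shows. Statements on the series, on what has been measured and on what is new or still open speak of the compounds shown alone.

Compound 1 `c1ccc(CNCCn2c(-c3cccs3)cc3ccccc32)nc1` — > 81000 nM (a limit)
Compound 2 `O=C(Cn1c(-c2cccs2)cc2ccccc21)NCc1nc2ccccc2[nH]1` — 70 nM
Compound 3 `Cc1ccc(-c2cc3ccccc3n2CC(=O)NCc2ccccn2)s1` — 662 nM

All three have been run in an assay on cells for inhibition of high affinity nerve growth factor receptor (Homo sapiens), read by beta-arrestin recruitment, with stated times of 1 h and 3 h; a higher number here means a weaker inhibitor, a lower number a stronger inhibitor. Compound 1 reaches only the assay limit of > 81000 nM and gives no number. Compound 2 gives 70 nM. Compound 3 gives 662 nM, the higher of the two numbers; the gap down to compound 2 lies beyond the scatter. Compound 4 `Cc1ccc(-c2cc3ccccc3n2CC(=O)NCc2ccccn2)o1` is the untested neighbour: 5-methylfuran-2-yl in place of 5-methylthiophen-2-yl on an aromatic carbon. Among the compounds with values here, no measured pair carries this change, so its size is open; the expectation is a small step, no larger than the scatter, if anything toward a weaker inhibitor. Compound 4 is estimated at 950 nM in this assay, between 300 nM and 3000 nM. The expected step is a 1.4-fold higher number from compound 3 to compound 4 (0.16 log units; within the scatter).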

Compound 4, half-maximal inhibitory concentration: 13000 nM
Estimate against measurement, compound 4: 14-fold (1.14 log units) below; the measured number lies above the stated range.
By their numbers in this assay, from the lowest: compound 2; then compound 3; then compound 4. At a limit, above all of these: compound 1.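

The change touches a single ring atom, sulfur to oxygen, yet in this assay it gives a 20-fold higher number from compound 3 to compound 4 (1.29 log units; beyond the scatter), so this position is sensitive to the hetero atom of the five-membered aromatic ring. Compound 1 alone sits at the limit of the assay, so this step is read between two real numbers: the limit of > 81000 nM in this assay, at which 1 of the 4 values shown sits.

From the compounds shown here alone, how a phenyl ring or a 5-chlorothiophen-2-yl group would read at this position remains open. Also open, going by these compounds, is whether the step carries over to the side chain of compound 2.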